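The compounds below may be only part of what the source reports. "The series", "measured", "known", "first", "only" and "open" are said of these compounds alone.

Measured so far in a physicochemical assay for solubility, at pH 5; on this read-out lower numbers stand for lower solubility and higher numbers for higher solubility:
- compound 1 `O=C(Nc1ncc(Cc2ccccn2)s1)C1CCCCC1`: 480 ug/mL
- compound 2 `O=C(Nc1ncc(Cc2ccncc2)s1)C1CCCCC1`: 1190 ug/mL

For the measured compounds named here, compound 2, at 1190 ug/mL, holds the higher of the two numbers in this assay, and compound 1 is its only neighbour. Next in the series is compound 3 `O=C(Nc1ncc(Cc2cccnc2)s1)C1CCCCC1`, which has the same atoms as compound 2, joined differently: pyridin-3-yl in place of pyridin-4-yl on a saturated chain carbon bound to an aromatic carbon. The change is pyridin-3-yl in place of pyridin-4-yl on a saturated chain carbon bound to an aromatic carbon.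

Going by the values given here, only one measured step bears on this, and it involves the same place and the same kind of exchange: a 2.5-fold higher number from compound 1 to compound 2 (0.39 log units; beyond the scatter). That step is modest but beyond the scatter. With compound 3 still unmeasured, the pyridin-3-yl group has no measured value of its own to draw on. The values of compound 1 and compound 2 therefore serve as the likely bounds, which leads to the expectation of a lower number than compound 2, by a step no larger than the measured one and possibly within the scatter. The expected step is a 1.6-fold lower number from compound 2 to compound 3 (0.20 log units; within the scatter). For compound 3 the estimated value is 750 ug/mL, with an expected range of 380 ug/mL to 1400 ug/mL.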

Compound 3, solubility: 590 ug/mL
The estimate for compound 3 lay 1.3-fold (0.10 log units) above the measured number; the range from low to high includes it.
By their numbers in this assay, from the lowest: compounds 1, 3 and 2 (each within the scatter of the next, the first and the last beyond it).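

In this assay, pyridin-3-yl gives this place on the saturated chain carbon a third reading, and it separates from neither of the other two groups: the steps are a 2.0-fold lower number from compound 2 to compound 3 (0.30 log units; within the scatter) and a 1.2-fold higher number from compound 1 to compound 3 (0.09 log units; within the scatter). Of the three pyridine attachments, only pyridin-2-yl and pyridin-4-yl stand clearly apart, by a 2.5-fold higher number from compound 1 to compound 2 (0.39 log units; beyond the scatter), so the single measured gap at this place is now bridged by a compound that lies within the scatter of both ends and cannot be ranked against either. For these three compounds, the exchange among pyridinyl groups therefore spans one modest step, and no measurement at hand accounts for the differences among them.

As far as these compounds go, it remains open whether a group without a ring nitrogen, such as phenyl, or a basic amine carried on the same saturated chain carbon would fall inside or outside the span set by compound 1 and compound 2. For the compounds shown here, also open is whether the same small span among the three pyridinyl groups would hold with a different acyl group on the shared core in place of the one these compounds carry.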